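Swapping a pyrazinyl for a fluorophenyl on the shared core

A few compounds are considered here, and "the series" means these few. Any claim that something is new, unique, unknown or untested is made for them only; others in the source may bear on it.

The series is followed in an assay on CHO cells for antagonist activity at Orexin receptor type 2 (Homo sapiens), read by FLIPR, with a stated time of 5 min; on this read-out higher numbers stand for weaker inhibition and lower numbers for stronger inhibition. Compound 1 `COc1ccc(CNC(=O)c2cc(-c3cncc(C)c3)ncc2-c2cncc(F)c2)nc1OC` gives 57 nM, and compound 2 `COc1ccc(CNC(=O)c2cc(-c3cncc(C)c3)ncc2-c2cnccn2)nc1OC` gives 109 nM. For the measured compounds named here, the only step measured so far, a 1.9-fold higher number from compound 1 to compound 2 (0.28 log units; within the scatter), leaves the two compounds within the usual scatter of each other, so no order between them can be claimed. Compound 2 thus stands beside compound 1 rather than apart from it.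

Compound 3 `COc1ccc(CNC(=O)c2cc(-c3cncc(C)c3)ncc2-c2ccccc2F)nc1OC` has not yet been measured. It differs from compound 2 in one place: 2-fluorophenyl in place of pyrazin-2-yl on an aromatic carbon.

Going by the values given here, only the step from compound 1 to compound 2 touches the same position, and it stayed within the scatter while exchanging one six-membered aromatic ring bearing nitrogen for another. The change to compound 3 is of a different kind, since the entering ring is built of carbon only, so that step is a weak guide. On this basis a step of about a 1.6-fold lower number from compound 2 to compound 3 (0.19 log units; within the scatter) is expected in this assay, without confidence in its direction. Compound 3 is therefore estimated at 70 nM, with a range from 20 nM to 250 nM.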

Compound 3, half-maximal inhibitory concentration: 25 nM
For compound 3 the middle estimate is 2.8-fold (0.45 log units) above the measured one; the measured number falls inside the stated range.
By their numbers in this assay, from the lowest: compound 3; then compounds 1 and 2 (each within the scatter of the next).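

The position on the shared core now separates its occupants in this assay, which the two nitrogen-bearing rings alone had not done: 2-fluorophenyl in place of pyrazin-2-yl gives a 4.4-fold lower number from compound 2 to compound 3 (0.64 log units; beyond the scatter) and, in place of 5-fluoropyridin-3-yl, gives a 2.3-fold lower number from compound 1 to compound 3 (0.36 log units; beyond the scatter). Among these three compounds, the ring of carbon only therefore stands apart from both nitrogen-bearing rings, which remain within the scatter of each other, and no compound here goes against that reading. No measurement bears on why this ring gives the lower number, and the step from compound 2 to compound 3 changes the ring atoms, the fluorine and the count of hydrogen-bond acceptors all at once.

These compounds do not separate the contribution of the carbon-only ring from that of its fluorine, a question that plain phenyl or 2-methylphenyl at this position would address. They also leave open whether the 2-fluorophenyl result would carry over if the 5-methylpyridin-3-yl group on the shared core were replaced by another group, such as a morpholine.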